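A few compounds are considered here, and "the series" means these few. Any claim that something is new, unique, unknown or untested is made for them only; others in the source may bear on it.

Among the measured compounds shown here, in a functional assay on A549 cells (Homo sapiens) for antiproliferative activity, read by MTT assay, with a stated time of 48 h (on this read-out higher numbers stand for weaker inhibition and lower numbers for stronger inhibition), compound 1 `COc1ccc(-c2cc3c(cn2)[nH]c(=O)n3-c2cc(OC)c(OC)c(OC)c2)cc1O` gives 630 nM, the lowest number among the three compounds measured so far. Compound 2 `COc1ccc(-c2cc3c(cn2)[nH]c(=O)n3-c2cc(OC)c(OC)c(OC)c2)cc1C` gives 1910 nM, and compound 3 `COc1ccc(-c2cc3c(cn2)[nH]c(=O)n3-c2cc(OC)c(OC)c(OC)c2)cc1C(=O)O` gives 1280 nM. Compound 1 leads this small set by modest margins, with a 3.0-fold higher number from compound 1 to compound 2 (0.48 log units; beyond the scatter) and a 2.0-fold higher number from compound 1 to compound 3 (0.31 log units; beyond the scatter), while a 1.5-fold lower number from compound 2 to compound 3 (0.17 log units; within the scatter) stays within the scatter.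

Compound 4 `CCn1c(=O)n(-c2cc(OC)c(OC)c(OC)c2)c2cc(-c3ccc(OC)c(O)c3)ncc21` has not yet been measured. It departs from compound 1 at a different place: ethyl in place of hydrogen on an aromatic nitrogen. For the measured compounds named here, none of the measured steps touches that nitrogen, since all three exchange groups on an aromatic carbon. They therefore bear on the new change only indirectly, showing that single exchanges elsewhere in this series have so far produced modest steps in this assay. The data offer no direction for substitution on the nitrogen, and a larger move in either direction cannot be excluded. The expected outcome is a 1.1-fold higher number from compound 1 to compound 4 (0.05 log units; within the scatter), a step not clearly beyond the scatter, though with wide uncertainty. For compound 4 the estimated value is 700 nM, with an expected range from 150 nM to 3000 nM.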

Compound 4, half-maximal inhibitory concentration: > 20000 nM
Compound 4: a limit, no number; the forecaster's own chance of this, stated with the estimate: 5%; middle value at least 28-fold (1.45 log units) from the limit.
By their numbers in this assay, from the lowest: compound 1; then compounds 3 and 2 (each within the scatter of the next). At a limit, above all of these: compound 4.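

In this assay, compound 4 gives > 20000 nM, which is a limit of the assay and not a number. Ethyl in place of hydrogen on the aromatic nitrogen of the five-membered ring produces an at least 31-fold higher number from compound 1 to compound 4 (1.50 log units; beyond the scatter), a large step, whereas the exchanges on an aromatic carbon among compound 1, compound 2 and compound 3 gave only modest steps or stayed within the scatter. Among the compounds shown here, this nitrogen, which none of the earlier steps touched, is thus the first place where a single change moves the read-out this far, and it tolerates this change far less well than the aromatic carbon tolerated its exchanges.

The compounds shown leave open whether methyl, a longer chain, or a chain ending in an amine or a carboxylic acid on this nitrogen would behave as ethyl does. From the compounds shown here alone, they also cannot separate the loss of the hydrogen from the arrival of the ethyl, and the true size of the step remains unknown while compound 4 stands at a limit.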